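Nitro Substitution on the Benzoyl Ring of a Thiourea Series

A few compounds are considered here, and "the series" means these few. Any claim that something is new, unique, unknown or untested is made for them only; others in the source may bear on it.

compound 1, `NC(=O)c1c(NC(=O)c2ccccc2)sc2c1CCN(C(=S)Nc1ccccc1Cl)C2`: 13800 nM
compound 2, `NC(=O)c1c(NC(=O)c2ccc(C(F)(F)F)cc2)sc2c1CCN(C(=O)Nc1ccccc1Cl)C2`: > 50000 nM

Among the measured compounds shown here, in a functional assay on HL-60 cells (Homo sapiens) for antiproliferative activity, with a stated time of 24 h (a lower number here means a stronger inhibitor, a higher number a weaker inhibitor), compound 1 gives 13800 nM, the only real number recorded so far. Compound 2 gives only a limit, > 50000 nM, which is the limit of > 50000 nM in this assay, at which 1 of the 2 values shown sits. For the measured compounds named here, compound 1 and compound 2 differ in more than one place, so their two values show no single step; they show only that compound 1 has a measured number where compound 2 has a limit.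

Compound 3, `NC(=O)c1c(NC(=O)c2cccc([N+](=O)[O-])c2)sc2c1CCN(C(=S)Nc1ccccc1Cl)C2`, differs from compound 1 in one place: nitro in place of hydrogen on an aromatic carbon. Cut one bond further out, the change reads benzoyl to (3-nitrophenyl)carbonyl. Going by the values given here, no measured step of this kind exists. For compound 3 no change beyond the scatter is expected, a 1.2-fold lower number from compound 1 to compound 3 (0.06 log units; within the scatter). Compound 3 is therefore estimated at 12000 nM, with a range from 4000 nM to 40000 nM.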

Compound 3, half-maximal inhibitory concentration: 7040 nM
Estimate against measurement, compound 3: 1.7-fold (0.23 log units) above; low and high end bracket the measured number.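

In this assay, the series now has its first step in a single place: a 2.0-fold lower number from compound 1 to compound 3 (0.29 log units; within the scatter). Nitro on an aromatic carbon, meta to a large group, therefore fits at this position with no change beyond the scatter, and compound 3 has a measured number, as compound 1 does. Nothing recorded here bears on a cause for this step.

One group at one position says nothing about whether an amine, a carboxylic acid or a longer chain at the same place would give a step beyond the scatter, or whether nitro would behave alike elsewhere on the ring. Among the compounds shown here, compound 2, at > 50000 nM, is a limit and not a number, and it differs from compound 1 and compound 3 in more than one place, so no step to it can be read.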